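The source may report more compounds than this note shows. Statements on the series, on what has been measured and on what is new or still open speak of the compounds shown alone.

Measured so far in a functional assay on PC-3 cells (Homo sapiens) for inhibition, read by sulforhodamine B assay, with a stated time of 48 h, tested at 50 uM; on this read-out lower numbers stand for less inhibition of growth and higher numbers for more inhibition of growth at the one concentration tested:
- compound 1 `COc1cc(/C=C/C(=O)/C=C/c2cccs2)ccc1OCc1cn(CCOc2cc(=O)oc3ccccc23)nn1`: 12%
- compound 2 `COc1cc(/C=C/C(=O)/C=C/c2ccccc2)ccc1OCc1cn(CCCCOc2cc(=O)oc3ccccc23)nn1`: "not active" (no number reported)
- compound 3 `COc1ccc(/C=C/C(=O)/C=C/c2ccc(OCc3cn(CCCCCOc4cc(=O)oc5ccccc45)nn3)c(OC)c2)cc1`: "not active" (no number reported)

Only compound 1 has a number at all, so it cannot be ranked numerically against the others. Its 12% shows only slight inhibition of growth at the single concentration tested. Compound 2 is reported as "not active" (no number reported), and compound 3 is also reported as "not active" (no number reported). The series therefore offers a low reading and two results without a number.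

The next compound to be tested is compound 4 `COc1ccc(/C=C/C(=O)/C=C/c2ccc(OCc3cn(CCOc4cc(=O)oc5ccccc45)nn3)c(OC)c2)cc1`. It differs from compound 1 by one swap: 4-methoxyphenyl in place of thiophen-2-yl on a double-bonded chain carbon bound to a double-bonded chain carbon. In other words, 4-methoxyphenyl takes the place of thiophen-2-yl on a double-bonded chain carbon bound to a double-bonded chain carbon.

Among the compounds with values here, no measured pair shows what this swap does in this assay, so the expectation rests on the low readings alone. With compound 1 at 12% and compound 3 at "not active" (no number reported), no large rise is expected, and any step should stay within the usual scatter. The expected step is a number 2 percentage points lower from compound 1 to compound 4 (within the scatter). For compound 4 the estimated value is 10%, with an expected range from 0% to 25%.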

Compound 4, percent growth inhibition at one concentration: 15%
For compound 4 the middle estimate is 5 percentage points below the measured one, and the stated range covers the measured number.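

In this assay, within the data shown here, putting 4-methoxyphenyl in place of thiophen-2-yl on a double-bonded chain carbon bound to a double-bonded chain carbon gives a number 3 percentage points higher from compound 1 to compound 4 (within the scatter), the first direct look at what a change at this position does. A five-membered aromatic ring with 1 hetero atom and a six-membered aromatic ring of carbon only therefore read alike here, even though the entering group has 8 heavy atoms against 5, and neither compound shows more than slight inhibition of growth at the one concentration tested. No measurement at hand explains why these two groups read alike.

Compound 4 shares its 4-methoxyphenyl with compound 3, which gives "not active" (no number reported), so no step can be read between those two compounds, nor between the other compounds without a number. As far as these compounds go, it also remains open whether a quite different group in this place, such as an amine or a carboxylic acid, would move the reading in this assay beyond the usual scatter.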